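Chloro replaces acetyl on the anilide of compound 3

A few compounds are considered here, and "the series" means these few. Any claim that something is new, unique, unknown or untested is made for them only; others in the source may bear on it.

Measured so far:
- compound 1 `COc1ccc(NC(=O)/C=C/C(=O)N2C/C(=C\c3ccc([N+](=O)[O-])cc3)C(=O)/C(=C/c3ccc([N+](=O)[O-])cc3)C2)cc1`: 2900 nM
- compound 2 `O=C(/C=C/C(=O)N1C/C(=C\c2ccccc2)C(=O)/C(=C/c2ccccc2)C1)Nc1ccc(Cl)c(Cl)c1`: 7500 nM
- compound 3 `CC(=O)c1ccc(NC(=O)/C=C/C(=O)N2C/C(=C\c3ccc([N+](=O)[O-])cc3)C(=O)/C(=C/c3ccc([N+](=O)[O-])cc3)C2)cc1`: 1400 nM

In a functional assay on L1210 cells (Mus musculus) for cytotoxicity (a lower number here means a stronger inhibitor, a higher number a weaker inhibitor), compound 3 gives the lowest of the three numbers. Compound 1 stands nearest to it, and compound 2 stands furthest away. The one single-point step among these three is a 2.1-fold lower number from compound 1 to compound 3 (0.32 log units; beyond the scatter), and it went towards a lower number.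

Compound 4 `O=C(/C=C/C(=O)N1C/C(=C\c2ccc([N+](=O)[O-])cc2)C(=O)/C(=C/c2ccc([N+](=O)[O-])cc2)C1)Nc1ccc(Cl)cc1` is not yet measured. It differs from compound 3 in one place: chloro in place of acetyl on an aromatic carbon. Among the compounds with values here, no measured step swaps acetyl for chloro, so the only bearing comes from compound 1 and compound 3, whose step shows that a change of the group on this aromatic carbon moves the number by a modest amount. Compound 2 carries chloro groups but also differs elsewhere, so its value alone cannot be read as a step.

For compound 4 a modest move towards a higher number is therefore expected, a 1.8-fold higher number from compound 3 to compound 4 (0.25 log units; within the scatter). Compound 4 is estimated at 2500 nM, with a range from 1000 nM to 6000 nM.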

Compound 4, half-maximal inhibitory concentration: 3600 nM
For compound 4 the middle estimate is 1.4-fold (0.16 log units) below the measured one, within the range that was stated.
By their numbers in this assay, from the lowest: compound 3; then compounds 1 and 4 (each within the scatter of the next); then compound 2.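

In this assay this aromatic carbon now carries a third group, and the change gives a 2.6-fold higher number from compound 3 to compound 4 (0.41 log units; beyond the scatter) in a modest move beyond the scatter, so acetyl keeps the lowest number of the three groups tried here. Chloro and methoxy cannot be told apart, as the comparison shows a 1.2-fold higher number from compound 1 to compound 4 (0.09 log units; within the scatter) and stays within the scatter, so the earlier step now reads as acetyl standing apart from both rather than as one end of a graded series. No measured evidence bears on why acetyl differs from the other two. 

Going by these compounds, it remains open whether another carbonyl group, such as a methyl ester or a carboxylic acid, would match acetyl here, or whether an amine would behave like chloro and methoxy. On these data alone, it is also open whether the same order holds on a core without the nitro groups.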